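A few compounds are considered here, and "the series" means these few. Any claim that something is new, unique, unknown or untested is made for them only; others in the source may bear on it.

Of the compounds shown here, three sharing the core of compound 1 have so far been measured in a functional assay on SK-BR-3 cells (Homo sapiens) for cytotoxicity, read by MTT assay, with a stated time of 72 h; a higher number here means a weaker inhibitor, a lower number a stronger inhibitor. Compound 1 `N[C@H]1CC[C@H](Nc2c(C(=O)NCc3ccc(Cl)cc3)nc(Br)c3cccnc23)CC1` gives 2000 nM. Compound 2 `Nc1ccc(Nc2c(C(=O)NCc3ccc(F)cc3)nc(Br)c3cccnc23)cc1` gives 4000 nM in this assay, and compound 3 `N[C@H]1CC[C@H](NC(=O)c2nc(Br)c3cccnc3c2NCc2ccc(F)cc2)CC1` gives 2800 nM. Compound 1 thus carries the smallest of the three numbers, but both other compounds sit within the scatter of it, so on this set the three cannot be told apart.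

Compound 4 `C[C@H](NC(=O)c1nc(Br)c2cccnc2c1N[C@H]1CC[C@H](N)CC1)c1ccc(F)cc1` has not yet been measured. It differs from compound 1 in one place: 1-(4-fluorophenyl)ethyl in place of 4-chlorobenzyl on an amide-type nitrogen. Among the measured compounds shown here, no pair of measured compounds differing only at the amide-type nitrogen is available, so there is no measured step to lean on. Given that the three compounds measured so far, for all their differences, fall within the scatter of one another in this assay, only a modest change is expected here as well. Compound 4 is estimated at 2500 nM, with a range from 1000 nM to 6000 nM. The expected step is a 1.3-fold higher number from compound 1 to compound 4 (0.10 log units; within the scatter), one that is expected to stay within the scatter, with no direction claimed beyond it.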

Compound 4, half-maximal inhibitory concentration: 9000 nM
The estimate for compound 4 lay 3.6-fold (0.56 log units) below the measured number; the whole stated range lies below it.
By their numbers in this assay, from the lowest: compounds 1, 3 and 2 (each within the scatter of the next); then compound 4.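

In this assay, the amide-type nitrogen emerges as a place where a single change can be read: 1-(4-fluorophenyl)ethyl in place of 4-chlorobenzyl gives a 4.5-fold higher number from compound 1 to compound 4 (0.65 log units; beyond the scatter). The earlier compounds shown here could not show this, since they lay within the scatter of one another and offered no pair differing in one place; now the group on this nitrogen is seen to shift the number, and the shift is towards a weaker inhibitor, though the step is modest. Nothing measured here bears on why the number rises.

The change swaps chlorine for fluorine and also brings in a defined stereocentre, so the compounds shown do not say which of the two carries the step; a 1-(4-chlorophenyl)ethyl group on the same nitrogen, with the rest of compound 1 kept, would separate them. Also open, as far as these compounds go, is how the mirror-image form of 1-(4-fluorophenyl)ethyl, or a longer chain such as 2-phenylethyl, would read at this position.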